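The source may report more compounds than this note shows. Statements on the series, on what has been measured and on what is new or still open speak of the compounds shown alone.

Measured so far:
- compound 1 `Oc1cccc(-c2cc(-c3ccc(Cl)cc3)nc(-c3cccs3)c2)c1`: 11800 nM
- compound 2 `Oc1ccc(-c2cc(-c3ccc(Cl)cc3)nc(-c3cccs3)c2)cc1`: 4520 nM
- compound 3 `Oc1cccc(-c2cc(-c3cccs3)nc(-c3ccccc3Cl)c2)c1`: 2600 nM

In an ADME assay on HEK293 cells (Homo sapiens) for cytotoxicity, read by CCK-8 assay and cell counting, with a stated time of 2 days (on this read-out lower numbers stand for stronger inhibition and higher numbers for weaker inhibition), compound 1 gives the highest number of the three. The nearest is compound 2, reached by a 2.6-fold lower number from compound 1 to compound 2 (0.42 log units; beyond the scatter); the furthest is compound 3, reached by a 4.5-fold lower number from compound 1 to compound 3 (0.66 log units; beyond the scatter).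

Compound 4 `Oc1cccc(-c2cc(-c3ccccc3)nc(-c3ccc(Cl)cc3)c2)c1` is not yet measured. It differs from compound 1 in one place: phenyl in place of thiophen-2-yl on an aromatic carbon.

Neither measured step bears on this change directly. Both concern the other two aryl groups on the shared core, and both gave lower numbers than compound 1, of modest size. Within the data shown here, the exchange of thiophen-2-yl for phenyl has no counterpart among the measured compounds, so the expectation rests only on the observation that every change so far from compound 1 has lowered the number, and on the limited size of those steps. A modest lowering, or no step beyond the scatter, is therefore expected in this assay, as a 1.7-fold lower number from compound 1 to compound 4 (0.23 log units; within the scatter). For compound 4 the estimate is 7000 nM, with a range from 3000 nM to 18000 nM.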

Compound 4, half-maximal inhibitory concentration: 11600 nM
Compound 4: middle estimate off by 1.7-fold (0.22 log units), on the low side; the measured number falls inside the stated range.
By their numbers in this assay, from the lowest: compounds 3 and 2 (each within the scatter of the next); then compounds 4 and 1 (each within the scatter of the next).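

In this assay, phenyl in place of thiophen-2-yl on the aromatic carbon next to the ring nitrogen gives a 1.0-fold lower number from compound 1 to compound 4 (0.01 log units; within the scatter). At this position, therefore, replacing the five-membered sulfur-containing ring with a six-membered ring of carbon only produces no step beyond the scatter, whereas the two changes to the other aryl groups did move the number beyond it. Nothing available on these compounds accounts for the absence of a step here.

On these data alone, it remains open whether a group of a different kind at this position, such as an amine, a carboxylic acid or a longer alkyl chain, would shift the number. Also open, as far as these compounds go, is whether the same exchange would leave the number unmoved with the 4-hydroxyphenyl group of compound 2 or the 2-chlorophenyl group of compound 3 in place.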